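The source may hold more compounds than are shown below. What is called first, only, known or untested is meant among the compounds shown, and "the series" means these compounds.

Of the compounds shown here, three of one family have so far been measured in a functional assay on A549 cells (Homo sapiens) for cytotoxicity, read by sulforhodamine B assay, with a stated time of 48 h; on this read-out higher numbers stand for weaker inhibition of growth and lower numbers for stronger inhibition of growth. Compound 1, `ClCc1cccc(Cn2cnc3c(Cl)ncnc32)c1`, gives 39800 nM. Compound 2, `ClCc1ccc(Cn2cnc3nc(Cl)nc(Cl)c32)cc1`, gives 4070 nM. Compound 3, `ClCc1cccc(Cn2cnc3c(Cl)nc(Cl)nc32)c1`, gives 10000 nM. Among these, compound 2 stands lowest: compound 3 is nearest to it and compound 1 furthest, and both gaps lie beyond the scatter. Compound 2 and compound 3 are built from the same atoms joined differently; the difference between the two cores is not broken down here.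

Compound 3 and compound 1 differ in a single place, (hydrogen in place of chloro on an aromatic carbon), and this change produced a 4.0-fold higher number from compound 3 to compound 1 (0.60 log units; beyond the scatter) in this assay.

Compound 4, `ClCc1ccc(Cn2cnc3ncnc(Cl)c32)cc1`, has not yet been measured. It is related to compound 2 by hydrogen in place of chloro on an aromatic carbon, the same change, at a place described in the same words as for the pair of compound 3 and compound 1. On the strength of a 4.0-fold higher number from compound 3 to compound 1 (0.60 log units; beyond the scatter), the step from compound 2 to compound 4 in this assay is expected to be a 3.9-fold higher number from compound 2 to compound 4 (0.59 log units; beyond the scatter). Compound 4 is therefore estimated to give about 16000 nM in this assay. Its expected range runs from 7000 nM to 40000 nM, since a single earlier step of this kind is a thin basis for the estimate.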

Compound 4, concentration for total growth inhibition: 4160 nM
The estimate for compound 4 lay 3.8-fold (0.59 log units) above the measured number; measured number outside the range, below it.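

In this assay, hydrogen in place of chloro on the aromatic carbon between two ring nitrogen atoms gave a 1.0-fold higher number from compound 2 to compound 4 (0.01 log units; within the scatter), so on this core the exchange leaves no difference that can be read. The size of this step therefore did not carry over from the core of compound 3 and compound 1 to the core of compound 2 and compound 4, and the two results disagree by more than repeated measurement would explain: the same change on two cores in this assay, a 4.0-fold higher number (0.60 log units; beyond the scatter) from compound 3 to compound 1 and a 1.0-fold higher number (0.01 log units; within the scatter) from compound 2 to compound 4, 3.9-fold (0.59 log units) apart, beyond the scatter of two such steps. This shows that, in this series, the step seen on one core is no safe guide to the other, but it does not show why, since it rests on a single pair for each core and the two pairs differ from each other in more than one place.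

The compounds shown carry only chloro or hydrogen on that aromatic carbon, so how an amine or a methoxy group there would read on either core remains open. All of them also keep the chloromethyl group, which leaves open what a hydroxymethyl group or a longer chain in its place would give, and whether the two cores would again part ways.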